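The compounds below may be only part of what the source reports. "The series", "measured", "known", "first", "only" and "open" are said of these compounds alone.

Compound 1, `C=CC1=C(C(=O)NCc2ccc(Cl)cc2)C(c2ccc(OC)cc2)OC1`: in a functional assay on SW480 cells (Homo sapiens) for cytotoxicity, read by MTT assay, with a stated time of 24 h (a lower number here means a stronger inhibitor, a higher number a weaker inhibitor), compound 1 gives > 100000 nM, which is a limit of the assay and not a number.
Compound 2, `C=CC1=C(C(=O)NC2CCCCC2)C(c2ccc(OC)cc2)OC1`: compound 2 gives > 100000 nM, again a limit.
Compound 3, `C=CC1=C(C(=O)NC2CCCCC2)C(c2ccc(F)cc2)OC1`: compound 3 gives > 100000 nM, also a limit.

Compound 2 thus stands at the limit of this assay, where every measured compound sits, as the limit of > 100000 nM in this assay, at which 3 of the 3 values shown sit, records; its position relative to compounds 1 and 3 cannot be fixed from these numbers. The two measured steps, a step that the two limits leave unreadable from compound 1 to compound 2 and a step that the two limits leave unreadable from compound 2 to compound 3, alter an amide substituent and an aromatic substituent, and neither has a readable size, since each joins two limits.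

Compound 4, `C=CC1=C(C(=O)O)C(c2ccc(OC)cc2)OC1`, differs from compound 2 by hydroxy in place of cyclohexylamino on a carbonyl carbon. Neither measured step touches the carbonyl carbon, so neither bears directly on this change; what the set shows so far is only that every variation tried leaves the compound at the limit. On that basis the step from compound 2 to compound 4 is expected to be a step that the limit leaves unreadable from compound 2 to compound 4, with the result most likely reported again as a limit rather than a number. Compound 4 is therefore estimated at 150000 nM, within a range from 50000 nM to 600000 nM.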

Compound 4, half-maximal inhibitory concentration: > 100000 nM
Compound 4 gave a limit, no number; the forecaster's own chance of this, stated with the estimate: 80%; the middle value does not contradict the limit.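

Compound 4 gives > 100000 nM in this assay, which is a limit of the assay and not a number, so no size can be read for its step from compound 2. The compounds shown leave open whether any change to them would give a readable number, and how they rank against one another, for all share one reading: the limit of > 100000 nM in this assay, at which 4 of the 4 values shown sit.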